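Sulfonyl aryl variation in a piperazinyl indazole 5-HT6 series

The compounds below may be only part of what the source reports. "The series", "measured", "known", "first", "only" and "open" are said of these compounds alone.

Measured compounds:
- compound 1 `CN1CCN(c2ccc3[nH]nc(S(=O)(=O)c4ccc(F)cc4)c3c2)CC1`: 5.2 nM
- compound 2 `O=S(=O)(c1cccc(F)c1)c1n[nH]c2cccc(N3CCNCC3)c12`: 134 nM
- compound 3 `CC(C)n1nc(S(=O)(=O)c2cccc3ccccc23)c2cc(N3CCN(C)CC3)ccc21`: 1.8 nM

The three compounds were run in an assay on HeLa cells for displacement of a labelled ligand from 5-hydroxytryptamine receptor 6 (Homo sapiens); a higher number here means a weaker inhibitor, a lower number a stronger inhibitor. Compound 1 gives 5.2 nM, the second highest of the three numbers. Its nearest neighbour is compound 3, whose number is lower by a margin beyond the scatter; its furthest is compound 2, whose number is higher by a wide margin, also beyond the scatter. Within the data shown here, no pair of the measured compounds differs in one place only, so none of these gaps can be read as a single-change step.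

Compound 4 `COc1cccc(S(=O)(=O)c2n[nH]c3ccc(N4CCN(C)CC4)cc23)c1` has not yet been measured. It is derived from compound 1 by one change: 3-methoxyphenyl in place of 4-fluorophenyl on a sulfonyl sulfur. Everything else, the shared core and the methylpiperazine, is kept.

Among the measured compounds shown here, with no measured one-place step to lean on, the expectation rests on compound 1 alone at 5.2 nM, and the step is expected to be small, within or only just beyond the scatter, more likely toward a slightly higher number than a lower one. The expected step from compound 1 is a 1.5-fold higher number from compound 1 to compound 4 (0.19 log units; within the scatter). Compound 4 is estimated at 8 nM, with a range from 2.5 nM to 25 nM.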

Compound 4, inhibition constant: 1.1 nM
Compound 4: middle estimate off by 7.3-fold (0.86 log units), on the high side; measured number outside the range, below it.
By their numbers in this assay, from the lowest: compounds 4 and 3 (each within the scatter of the next); then compound 1; then compound 2.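

In this assay, replacing 4-fluorophenyl with 3-methoxyphenyl on a sulfonyl sulfur gives a 4.7-fold lower number from compound 1 to compound 4 (0.67 log units; beyond the scatter). Among these compounds, this is the first single-change step in the set: the earlier compounds differ from one another in more than one place, whereas here the shared core and the methylpiperazine stay fixed, so this gap belongs to the aryl group alone and shows that the number at this position responds to the choice of that group. The change adds one heavy atom and one hydrogen-bond acceptor and exchanges fluorine for oxygen, but no measurement here bears on what lies behind the step.

A single step cannot separate the identity of the substituent from its place on the ring, and a 4-methoxyphenyl group and an unsubstituted phenyl group on the same sulfonyl sulfur would be the direct comparisons for that question. On these data alone, whether the 3-methoxyphenyl group would give a step of similar size on the other scaffolds in the set, including the one carrying the unsubstituted piperazine, also remains open.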